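Losing one fluorine at the ceiling of the assay

A few compounds are considered here, and "the series" means these few. Any claim that something is new, unique, unknown or untested is made for them only; others in the source may bear on it.

In an ADME assay on cells (Peritoneal macrophage cell, Mus musculus) for cytotoxicity, read by fluorescence and resazurin assay, with a stated time of 3 days (a lower number here means that less compound is tolerated, a higher number that more compound is tolerated), compound 1 (`N#Cc1ccc(OC2CCN(C(=O)Nc3cc(-c4ccccn4)n[nH]3)CC2)cc1`) gives > 64000 nM as a limit of the assay. Compound 2 (`O=C(Nc1cc(-c2ccccn2)n[nH]1)N1CCC(c2ccc(F)cc2)CC1`) likewise gives > 64000 nM as a limit and has no exact number. For the measured compounds named here, the only measured step is a step that the two limits leave unreadable from compound 1 to compound 2 and it offers no size to carry over. All that is known is the limit of > 64000 nM in this assay, at which 2 of the 2 values shown sit, and no size of effect follows from it. Compound 3 (`O=C(Nc1cc(-c2ccccn2)n[nH]1)N1CCC(c2ccccc2)CC1`) has hydrogen in place of fluoro on an aromatic carbon and keeps the rest of compound 2. In this assay the expected change is a number no higher from compound 2 to compound 3 (the limit leaves the size open) and so none beyond the scatter. For compound 3 the expected value is 64000 nM with 30000 nM to 100000 nM as the estimated range.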

Compound 3, half-maximal cytotoxic concentration: > 64000 nM
Compound 3: a limit, no number (the forecaster's own chance of this, stated with the estimate: 85%); the middle value lies on the limit itself.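

For the compounds shown here, compound 3 gives > 64000 nM, a limit and not a number, and no step among compound 1, compound 2 and compound 3 can be read. How far the three half-maximal cytotoxic concentrations lie past that limit, and whether the fluoro or 4-cyanophenoxy groups make any difference, stays open: the limit of > 64000 nM in this assay, at which 3 of the 3 values shown sit.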